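The source may hold more compounds than are shown below. What is called first, only, known or untested is meant among the compounds shown, and "the series" means these compounds.

Measured so far in an ADME assay on cells (Homo sapiens) for cytotoxicity, read by polymerase chain reaction, with a stated time of 3 days; on this read-out lower numbers stand for higher toxicity in this test and higher numbers for lower toxicity in this test:
- compound 1 `Cc1nc(N[C@H](C)c2ccc(OC(F)(F)F)cc2)nc(N[C@@H]2C[C@H](CO)[C@@H](O)[C@H]2O)c1-c1nc2c(C(C)C)nccc2s1`: 11000 nM
- compound 2 `Cc1nc(N[C@H](C)c2ccc(OC(F)(F)F)cc2)nc(N[C@@H]2C[C@H](CO)[C@@H](O)[C@H]2O)c1-c1nc2c(CC(C)(C)C)nccc2s1`: 10000 nM

Among the compounds with values here, only two compounds have numbers in this assay. Compound 1 stands at 11000 nM, and it lies within the scatter of compound 2, so the two cannot be ranked. The next compound to be tested is compound 3 `CCc1nc(C)cc2sc(-c3c(C)nc(N[C@H](C)c4ccc(OC(F)(F)F)cc4)nc3N[C@@H]3C[C@H](CO)[C@@H](O)[C@H]3O)nc12`, which has the same atoms as compound 1, joined differently. The change is a group of 12 heavy atoms (9 carbon, 2 nitrogen, 1 sulfur; one five-membered aromatic ring with 2 hetero atoms, one six-membered aromatic ring with 1 hetero atom) in place of a group of 12 heavy atoms (9 carbon, 2 nitrogen, 1 sulfur; one five-membered aromatic ring with 2 hetero atoms, one six-membered aromatic ring with 1 hetero atom), on an aromatic carbon. It sits on an aromatic carbon of a six-membered aromatic ring with 2 nitrogen, para to a large group in the wording of the comparison, and the rest of the molecule is untouched.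

Within the data shown here, one measured step bears on this: neopentyl in place of isopropyl on an aromatic carbon, which gave a 1.1-fold lower number from compound 1 to compound 2 (0.04 log units; within the scatter). That step concerns the same part of the molecule and stays within the scatter. With compound 2 at 10000 nM, no step beyond the scatter is expected in this assay, and no direction can be given with confidence. The estimate means a 1.1-fold lower number from compound 1 to compound 3 (0.04 log units; within the scatter), an expected step that stays inside the scatter. For compound 3 the expected value is 10000 nM, with an estimated range of 5000 nM to 20000 nM.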

Compound 3, half-maximal cytotoxic concentration: 23000 nM
For compound 3 the middle estimate is 2.3-fold (0.36 log units) below the measured one; the measured number lies above the stated range.
By their numbers in this assay, from the lowest: compounds 2 and 1 (each within the scatter of the next); then compound 3.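

In this assay, the group on the aromatic carbon of the six-membered ring with 2 nitrogen was replaced by one with the same atoms joined differently, and this gave a 2.1-fold higher number from compound 1 to compound 3 (0.32 log units; beyond the scatter). The count of heavy atoms, the ring types, the 3 hydrogen-bond acceptors and the absence of net charge all stay the same across this change, so the number at this position can move beyond the scatter, if only modestly, without any change in those counts; the earlier step, neopentyl in place of isopropyl, gave only a 1.1-fold lower number from compound 1 to compound 2 (0.04 log units; within the scatter) and did not show this. Nothing available here accounts for the shift in terms of any measured property of the two groups.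

The compounds shown leave open how far the number at this position can move, since each group here is a fused pair of aromatic rings carrying only small alkyl substituents. Whether a primary amine or a carboxylic acid on that group would take the number further in the same direction, reverse it or leave it within the scatter remains unanswered.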